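Swapping the Amide Substituent: Outlook for Compound 4

The compounds below may be only part of what the source reports. "The series", "measured", "known", "first", "only" and "open" are said of these compounds alone.

Compound 2 `COc1ccc2nc(C)cc(OCC(=O)Nc3ccc(Cl)c(OC)c3)c2c1` is one of three compounds tested in a physicochemical assay for solubility, in phosphate buffer, measured as kinetic solubility, with a stated time of 1 h, at pH 7.4; on this read-out lower numbers stand for lower solubility and higher numbers for higher solubility. In this assay compound 2 gives 13000 nM, the second highest of the three numbers. Compound 1 `COc1ccc2nc(C)cc(OCC(=O)Nc3ccc(Cl)c(C(F)(F)F)c3)c2c1` gives 17000 nM, and the step of a 1.3-fold lower number from compound 1 to compound 2 (0.12 log units; within the scatter) stays within the scatter. Compound 3 `COc1ccc2nc(C)cc(OCC(=O)Nc3cc(OC)c(Cl)cc3OC)c2c1` gives 3000 nM, so the step of a 4.3-fold lower number from compound 2 to compound 3 (0.64 log units; beyond the scatter) is a modest drop beyond the scatter.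

Compound 4 `COc1ccc2nc(C)cc(OCC(=O)NNC(=O)c3ccncc3)c2c1` differs from compound 2 by ((pyridin-4-yl)carbonyl)amino in place of 4-chloro-3-methoxyphenyl on an amide-type nitrogen. Both measured steps altered only a single substituent on the aromatic ring that is now exchanged entirely, and one was within the scatter while the other was a modest drop. Neither matches the swap of a whole ring for a different one, so they give only a loose guide. For compound 4 the expected step is a 3.1-fold higher number from compound 2 to compound 4 (0.49 log units; beyond the scatter), with wide uncertainty. Compound 4 is estimated at 40000 nM, in a range from 10000 nM to 150000 nM.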

Compound 4, solubility: >= 375000 nM
Compound 4: no number, only a limit; the forecaster's own chance of this, stated with the estimate: 10%; at least 9.3-fold (0.97 log units) between middle value and limit.
By their numbers in this assay, from the lowest: compound 3; then compounds 2 and 1 (each within the scatter of the next). At a limit, above all of these: compound 4.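

Compound 4 has no exact number in this assay, only a limit: the limit of >= 375000 nM in this assay, at which 1 of the 4 values shown sits.

Replacing the whole 4-chloro-3-methoxyphenyl with ((pyridin-4-yl)carbonyl)amino on the amide-type nitrogen gives an at least 28-fold higher number from compound 2 to compound 4 (1.46 log units; beyond the scatter), a large step. This step rests on a limit, so it gives only a minimum size. The earlier steps shown here changed one substituent on the aromatic ring and showed nothing of this size, so this position can move the read-out much further than those small edits suggested.

This one change brings in a ring nitrogen, a carbonyl and an amino link together, so the compounds shown cannot tell which of these parts goes with the step. A (phenylcarbonyl)amino group, with a ring of carbon only, or a pyridin-4-yl set directly on the amide-type nitrogen, would begin to separate them.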